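Methoxy for fluoro on the aryl of compound 2

The compounds below may be only part of what the source reports. "The series", "measured", "known", "first", "only" and "open" are said of these compounds alone.

Compound 1 `Cc1cccc(-c2noc(C3CC(=O)N(c4ccc(F)cc4)C3)n2)n1` reaches only a limit in an in vitro functional assay on HEK293-A cells for positive allosteric modulation of metabotropic glutamate receptor 5 (Homo sapiens), read by FLIPR and calcium flux (on this read-out lower numbers stand for an effect already at smaller amounts and higher numbers for an effect only at larger amounts of compound), with compound 1 giving > 10000 nM, a limit of that measurement rather than a number (the limit of > 10000 nM in this assay, at which 1 of the 2 values shown sits). Compound 2 `O=C1CC(c2nc(-c3cccc(F)c3)no2)CN1c1ccc(F)cc1` gives 88 nM in this assay, which is the only number shown. Among the measured compounds shown here, the one measured step, an at least 110-fold lower number from compound 1 to compound 2 (2.05 log units; beyond the scatter), is large and goes beyond the scatter, but it exchanges the whole aryl group.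

Compound 3 `COc1cccc(-c2noc(C3CC(=O)N(c4ccc(F)cc4)C3)n2)c1` differs from compound 2 by methoxy in place of fluoro on an aromatic carbon. For the measured compounds named here, no measured step exchanges one substituent for another on this ring, so the large step from compound 1 to compound 2 bears on it only loosely and does not fix a direction. The expected step is therefore small in this assay, a 1.7-fold higher number from compound 2 to compound 3 (0.23 log units; within the scatter), with the number expected to stay close to that of compound 2, and no direction beyond the scatter is claimed. For compound 3 the estimate in this assay is 150 nM, expected to lie between 40 nM and 700 nM.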

Compound 3, half-maximal effective concentration: 1100 nM
Compound 3: middle estimate off by 7.3-fold (0.87 log units), on the low side; the measured number lies above the stated range.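

Among the compounds shown here, the fluoro on the aryl of compound 2 cannot be swapped freely in this assay: methoxy in its place gives a 13-fold higher number from compound 2 to compound 3 (1.10 log units; beyond the scatter), the first measured exchange of one substituent for another on this ring, and it shows that the position meta to a large group responds strongly to this change. The 3-methoxyphenyl group nevertheless keeps a measured effect, which the 6-methylpyridin-2-yl group does not, with an at least 9.0-fold lower number from compound 1 to compound 3 (0.95 log units; beyond the scatter), so this aryl still stands apart from the pyridine even with the fluoro gone. Compound 1 stands at a limit of the assay and not at a number, so this second step gives only a bound on the gap: the limit of > 10000 nM in this assay, at which 1 of the 3 values shown sits.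

The compounds shown cannot separate the extra heavy atom of the methoxy from its hydrogen-bond acceptor as the source of the step, and an ethyl or a hydroxyl group in the same place would be needed to tell these apart. From the compounds shown here alone, whether a chlorine or a methyl group there would stay close to compound 2 or fall nearer compound 3 also remains open.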